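A few compounds are considered here, and "the series" means these few. Any claim that something is new, unique, unknown or untested is made for them only; others in the source may bear on it.

Measured in a functional assay on HCT-15 cells (Homo sapiens) for cytotoxicity, read by MTT assay, with a stated time of 2 days; a lower number here means a stronger inhibitor, a higher number a weaker inhibitor:

- compound 1 `CN(C)c1ccc2nc(-c3cccc4ccccc34)[nH]c(=O)c2c1`: 460 nM
- compound 2 `Cc1cccc(-c2nc3ccc(C)cc3c(=O)[nH]2)c1`: > 50000 nM

Among the measured compounds shown here, compound 1 holds the only actual number in this assay, at 460 nM. For compound 2 the entry > 50000 nM is a limit of the assay and not a number. Compound 1 therefore has no second number to be ranked against, and it serves as the reference point for what follows.

The next compound to be tested is compound 3 `O=c1[nH]c(-c2cccc3ccccc23)nc2ccc(N3CCCCC3)cc12`, which keeps the core of compound 1 and carries piperidin-1-yl in place of dimethylamino on an aromatic carbon. For the measured compounds named here, no two measured compounds differ in one place only, so no measured step gives the size of this change. The expectation in this assay is therefore a small loss of potency, possibly no more than the scatter, and it rests on compound 1 at 460 nM. The estimated change is a 1.4-fold higher number from compound 1 to compound 3 (0.15 log units; within the scatter), and this expected step is modest. For compound 3 the estimated value is 650 nM, with an expected range from 150 nM to 3500 nM.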

Compound 3, half-maximal inhibitory concentration: 2240 nM
Compound 3: middle estimate off by 3.4-fold (0.54 log units), on the low side; low and high end bracket the measured number.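

In this assay, among the compounds shown here, the replacement of dimethylamino by piperidin-1-yl gives the first measured step at this aromatic carbon, and it is a real loss of potency: a 4.9-fold higher number from compound 1 to compound 3 (0.69 log units; beyond the scatter). For the compounds shown here, this shows that the position is sensitive to the amine it carries, a point the earlier compounds could not settle because none of them formed a one-place pair. It also shows that the position accepts a six-membered non-aromatic ring with more heavy atoms than dimethylamino and still gives a measured number, with compound 3 at 2240 nM, although nothing shown here accounts for the size of the step.

As far as these compounds go, it remains open whether the ring itself or simply the added carbon atoms produce this step, and diethylamino, pyrrolidin-1-yl and morpholin-4-yl at the same carbon would help to separate the two. With a single one-place pair, it is also unknown whether the same change would have a step of similar size on a core bearing a different aryl group.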